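The source may report more compounds than this note shows. Statements on the series, on what has been measured and on what is new or still open speak of the compounds shown alone.

For the measured compounds named here, the three compounds measured so far share one core and differ only in the group on the six-membered aromatic ring of carbon only. Compound 1 `CC(C)(C)c1ccc(C(=O)/C=C/c2ccncc2)cc1` carries a tert-butyl group, and in a functional assay with Rattus norvegicus as the target (a higher number here means a weaker inhibitor, a lower number a stronger inhibitor), compound 1 gives 47000 nM. Compound 2 `CN(C)c1cccc(C(=O)/C=C/c2ccncc2)c1` carries a dimethylamino group, and in this assay compound 2 gives 19000 nM. Compound 3 `O=C(/C=C/c1ccncc1)c1cccc(Cl)c1` carries a chloro group, and in this assay compound 3 gives 69000 nM. Among these three numbers compound 1 stands second highest: its value and that of compound 3 lie within the scatter of each other, while compound 2 gives a lower number than compound 1 by a margin beyond the scatter. Going by the values given here, the only single-point step measured is a 3.6-fold higher number from compound 2 to compound 3 (0.56 log units; beyond the scatter).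

Compound 4 `O=C(/C=C/c1ccncc1)c1ccc(Cl)cc1` is not yet measured. It differs from compound 1 in one place: chloro in place of tert-butyl on an aromatic carbon. Among the compounds with values here, no measured step swaps tert-butyl for chloro, so the nearest guide is that compound 3, which also carries chloro, sits within the scatter of compound 1. The measured step from dimethylamino to chloro raised the number, but it does not involve tert-butyl. The step from compound 1 to compound 4 is therefore expected to be small, a 1.3-fold higher number from compound 1 to compound 4 (0.11 log units; within the scatter), with no clear direction beyond the scatter. Compound 4 is estimated at 60000 nM, with a range from 25000 nM to 150000 nM.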

Compound 4, half-maximal inhibitory concentration: 60000 nM
Compound 4: the middle estimate sits on the measured number at the digits printed; measured number inside the range.
By their numbers in this assay, from the lowest: compound 2; then compounds 1, 4 and 3 (each within the scatter of the next).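

Placing chloro in place of tert-butyl, on an aromatic carbon para to a large group, gives a 1.3-fold higher number from compound 1 to compound 4 (0.11 log units; within the scatter) and provides the first direct reading of this swap in this assay. The group that leaves has 4 heavy atoms and the group that enters has 1 heavy atom, yet this large drop in group size leaves the number within the scatter, so between these two groups the assay does not distinguish the larger from the smaller at this place. Neither group has a ring, a hydrogen-bond donor, a hydrogen-bond acceptor or a net charge, and nothing measured here accounts for the two compounds reading alike.

Going by these compounds, both groups at this place share those counts, so it remains open whether a group of another kind here, such as a primary amine or a carboxylic acid, would move the number beyond the scatter. For the compounds shown here, compound 2 gives the lowest number so far at 19000 nM but differs from compound 1 and compound 4 in more than one place, so whether its dimethylamino group would give a similar number at this place also stays unresolved.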